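This account rests on a few compounds, and the source may have more. Where it says the series, first, only, none or still open, it means among the compounds named here.

Compound 1 `COc1ccc(C2CC(C3C(=O)c4ccccc4C3=O)=NC(=O)N2)cc1` carries a 4-methoxyphenyl group on a saturated ring carbon of its shared core. In a functional assay on the whole organism for inhibition, with Rattus norvegicus as the target, read by paw edema, with stated times of 30 min and 1 h, at a dose of 10 mg/kg by the oral route (on this read-out lower numbers stand for less inhibition and higher numbers for more inhibition at the one dose given (going by the name of the read-out)), compound 1 gives 22%. For the measured compounds named here, two companions change only that group. Compound 2 `O=C1N=C(C2C(=O)c3ccccc3C2=O)CC(c2cccc([N+](=O)[O-])c2)N1` gives 27% in this assay, and compound 3 `O=C1N=C(C2C(=O)c3ccccc3C2=O)CC(/C=C/c2ccccc2)N1` gives 17%. All three numbers sit close together: the step of a number 5 percentage points higher from compound 1 to compound 2 (within the scatter) and the step of a number 5 percentage points lower from compound 1 to compound 3 (within the scatter) both stay within the scatter, as does the step of a number 10 percentage points lower from compound 2 to compound 3 (within the scatter). On the numbers shown, compound 1 therefore sits in the middle of a narrow cluster.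

Compound 4 `O=C1N=C(C2C(=O)c3ccccc3C2=O)CC(c2ccco2)N1` differs from compound 1 by furan-2-yl in place of 4-methoxyphenyl on a saturated ring carbon. The two measured steps that bear on this change are those from compound 1 to compound 2 and from compound 1 to compound 3, which swap the same group on the same saturated ring carbon, and neither moved the read-out beyond the scatter. The expectation for compound 4 is therefore a step of about a number 1 percentage points lower from compound 1 to compound 4 (within the scatter) in this assay, which means no change beyond the scatter. Compound 4 is estimated at 21%, within a range from 9% to 33%.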

Compound 4, a percentage reported as inhibition, in the whole organism at one dose (the size of the read-out at that dose, not a potency): 18%
The estimate for compound 4 lay 3 percentage points above the measured number; measured number inside the range.
By their numbers in this assay, from the lowest: compounds 3, 4, 1 and 2 (each within the scatter of the next).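

In this assay, furan-2-yl on this saturated ring carbon stays within the scatter of all three earlier groups: the readings are a number 4 percentage points lower from compound 1 to compound 4 (within the scatter), a number 1 percentage points higher from compound 3 to compound 4 (within the scatter) and a number 9 percentage points lower from compound 2 to compound 4 (within the scatter). For the compounds shown here, the position has now carried a five-membered aromatic ring with 1 hetero atom, a group of 5 heavy atoms in place of the 8 in 4-methoxyphenyl, and still no step goes beyond the scatter. No measurement here explains why these groups read alike.

Going by these compounds, it remains open whether an amine, a carboxylic acid or a longer alkyl chain on this carbon would move the read-out beyond the scatter. All the compounds shown differ only at this one carbon, so the effect of a change elsewhere on the shared core also remains open.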